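From 2,5-dimethylphenyl to 3-methoxyphenyl on the sulfonamide

The compounds below may be only part of what the source reports. "The series", "measured", "known", "first", "only" and "open" are said of these compounds alone.

In a functional assay on M21 cells (Homo sapiens) for antiproliferative activity, read by sulforhodamine B assay, with a stated time of 48 h (a higher number here means a weaker inhibitor, a lower number a stronger inhibitor), compound 1 (`Cc1ccc(NS(=O)(=O)c2ccc(N3CCNC3=O)cc2)cc1`) gives 260 nM and compound 2 (`O=C1NCCN1c1ccc(S(=O)(=O)Nc2ccc(I)cc2)cc1`) gives 260 nM with no separation between them (no change at the digits printed from compound 1 to compound 2 (within the scatter)). Compound 3 (`Cc1ccc(C)c(NS(=O)(=O)c2ccc(N3CCNC3=O)cc2)c1`) at 27 nM is the lowest of the three. Compound 4 (`COc1cccc(NS(=O)(=O)c2ccc(N3CCNC3=O)cc2)c1`) carries 3-methoxyphenyl in place of 2,5-dimethylphenyl on a sulfonamide nitrogen. Two modest steps bear on this (a 9.6-fold lower number from compound 1 to compound 3 (0.98 log units; beyond the scatter) and a 9.6-fold lower number from compound 2 to compound 3 (0.98 log units; beyond the scatter)). Each brings in 2,5-dimethylphenyl, and compound 4 gives that group up again. Within the data shown here, no compound with a methoxy group has been measured, so the reverse of those steps is only a rough guide. A higher number is therefore expected (a 6.7-fold higher number from compound 3 to compound 4 (0.82 log units; beyond the scatter)), perhaps somewhat short of their size. Compound 4 is estimated at 180 nM (range 50 nM to 600 nM).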

Compound 4, half-maximal inhibitory concentration: 65 nM
Estimate against measurement, compound 4: 2.8-fold (0.44 log units) above, within the range that was stated.
By their numbers in this assay, from the lowest: compound 3; then compound 4; then compounds 1 and 2 (each within the scatter of the next).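

In this assay, 3-methoxyphenyl on the sulfonamide nitrogen keeps part of the gain over 4-methylphenyl and 4-iodophenyl, with a 4.0-fold lower number from compound 1 to compound 4 (0.60 log units; beyond the scatter) and a 4.0-fold lower number from compound 2 to compound 4 (0.60 log units; beyond the scatter). 2,5-Dimethylphenyl still stays ahead, with a 2.4-fold higher number from compound 3 to compound 4 (0.38 log units; beyond the scatter), so a gain over compounds 1 and 2 is not confined to 2,5-dimethylphenyl. Nothing measured here accounts for these steps.

Open, from the compounds shown here alone, is whether the gain of compound 4 would survive an amine or a carboxylic acid in place of the methoxy group. Also open, going by these compounds, is how 2,5-dimethoxyphenyl would compare with compound 3.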